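The source may report more compounds than this note shows. Statements on the series, on what has been measured and on what is new or still open speak of the compounds shown alone.

Compound 2 `Fc1ccc2nc(-c3cn[nH]c3)n(C3CC3)c2c1` stands second highest of the three numbers in an assay on cells for inhibition of cytochrome P450 11B2, mitochondrial (Homo sapiens), read by HPLC, with a stated time of 90 min (on this read-out higher numbers stand for weaker inhibition and lower numbers for stronger inhibition), where compound 2 gives 782 nM. Its nearest neighbour is compound 1 `Fc1ccc2nc(-n3ccnn3)n(C3CC3)c2c1`, which gives 1060 nM, so that a 1.4-fold lower number from compound 1 to compound 2 (0.13 log units; within the scatter); its furthest is compound 3 `Fc1ccc2nc(-c3cncnc3)n(C3CC3)c2c1`, which gives 40 nM, a gap of a 20-fold lower number from compound 2 to compound 3 (1.29 log units; beyond the scatter). Compound 4 `Fc1ccc2nc(-c3cccnn3)n(C3CC3)c2c1` is the next step from compound 2: pyridazin-3-yl in place of 1H-pyrazol-4-yl on an aromatic carbon. Among the measured compounds shown here, two measured steps bear on it, both exchanging a five-membered ring for a six-membered ring with two nitrogen atoms, as here: a 20-fold lower number from compound 2 to compound 3 (1.29 log units; beyond the scatter) and a 27-fold lower number from compound 1 to compound 3 (1.42 log units; beyond the scatter). A lowering step beyond the scatter is therefore expected in this assay, though the entering ring is not the one measured. Compound 4 is expected to give 120 nM, between 40 nM and 400 nM. The expected step is a 6.5-fold lower number from compound 2 to compound 4 (0.81 log units; beyond the scatter).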

Compound 4, half-maximal inhibitory concentration: 412 nM
Compound 4: the middle estimate sits 3.4-fold (0.54 log units) below what was measured, and the stated range ends below it.
By their numbers in this assay, from the lowest: compound 3; then compounds 4, 2 and 1 (each within the scatter of the next, the first and the last beyond it).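

In this assay, exchanging the five-membered ring for a six-membered aromatic ring with 2 hetero atoms does not by itself bring the large step seen with pyrimidin-5-yl: pyridazin-3-yl stays level with 1H-pyrazol-4-yl (a 1.9-fold lower number from compound 2 to compound 4 (0.28 log units; within the scatter)). The two six-membered rings are not interchangeable at this position (a 10-fold higher number from compound 3 to compound 4 (1.01 log units; beyond the scatter)), while pyridazin-3-yl retains only a modest step over 1H-1,2,3-triazol-1-yl (a 2.6-fold lower number from compound 1 to compound 4 (0.41 log units; beyond the scatter)). Nothing given here accounts for the difference between these rings. The compounds shown leave open how a pyridin-3-yl ring would compare, and whether an amine on pyrimidin-5-yl would change the number in this assay.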